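Compound 3 gains a chloro: reading past a limit

This account rests on a few compounds, and the source may have more. Where it says the series, first, only, none or still open, it means among the compounds named here.

Compound 1 `Nc1c(C2=NCCN2)cnn1-c1ccccc1`: > 500000 nM (a limit)
Compound 2 `Nc1c(C2=NCCN2)cnn1-c1cccc(Cl)c1`: > 500000 nM (a limit)
Compound 3 `Nc1c(C2=NCCCN2)cnn1-c1ccccc1`: > 500000 nM (a limit)

These compounds were all tested in an ADME assay on Vero cells (Chlorocebus sabaeus) for cytotoxicity, read by CellTiter-Glo and ATP content, with a stated time of 72 h; on this read-out higher numbers stand for lower toxicity in this test and lower numbers for higher toxicity in this test. There compound 3 gives > 500000 nM, which is a limit of the assay and not a number. The picture is the same across the set, with the limit of > 500000 nM in this assay, at which 3 of the 3 values shown sit. Compound 3 therefore has no exact position of its own, only a shared one.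

Compound 4 `Nc1c(C2=NCCCN2)cnn1-c1cccc(Cl)c1` differs from compound 3 in one place: chloro in place of hydrogen on an aromatic carbon. In words, chloro takes the place of hydrogen on an aromatic carbon, meta to a large group.

The same exchange has been measured once, as a step that the two limits leave unreadable from compound 1 to compound 2. This is the closest guide, although it gives no size. The other measured step, a step that the two limits leave unreadable from compound 1 to compound 3, concerns a different part of the molecule and also gives no size. In both steps, each compound stays at the limit.

In this assay, then, no step beyond the scatter is expected in either direction, and another limit is the likeliest report. The estimated change is a number no higher from compound 3 to compound 4 (the limit leaves the size open). Compound 4 is estimated at 500000 nM, with an expected range from 250000 nM to 1000000 nM.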

Compound 4, half-maximal cytotoxic concentration: > 500000 nM
Compound 4 was reported as a limit; the forecaster's own chance of this, stated with the estimate: 85%; the middle value sits exactly at the limit.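

In this assay compound 4 gives > 500000 nM, which is a limit of the assay and not a number. No new step can be read between compound 3 and compound 4, or between compound 2 and compound 4, since both members of each pair are limits. The compounds shown leave open whether the chloro or the six-membered ring changes this read-out at all, and by how much: the limit of > 500000 nM in this assay, at which 4 of the 4 values shown sit.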